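From benzyl to 4-methoxyphenyl on the ring nitrogen

The source may report more compounds than this note shows. Statements on the series, on what has been measured and on what is new or still open speak of the compounds shown alone.

- Compound 1 `COc1cc(-c2nccn2S(=O)(=O)c2ccc(C)cc2)cc(OC)c1OC` gives > 100000 nM as a limit
- Compound 2 `COc1cc(-c2nccn2Cc2ccccc2)cc(OC)c1OC` gives > 100000 nM as a limit

Both entries come from a functional assay on HeLa cells (Homo sapiens) for antiproliferative activity, read by MTT assay, with a stated time of 72 h (a higher number here means a weaker inhibitor, a lower number a stronger inhibitor), and neither is a number. Compound 2 therefore has no value of its own and stands with compound 1 at the limit of > 100000 nM in this assay, at which 2 of the 2 values shown sit, in the data so far. Among the measured compounds shown here, no step between measured compounds is available, so no change has a measured size.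

Compound 3 `COc1ccc(-n2ccnc2-c2cc(OC)c(OC)c(OC)c2)cc1` keeps the shared core of compound 2 and carries 4-methoxyphenyl in place of benzyl on an aromatic nitrogen, next to the ring atom that bears a large group. The counted difference is 4-methoxyphenyl in place of benzyl on an aromatic nitrogen in full.

Compound 2 gives > 100000 nM as a limit, so only a move toward stronger inhibition could be read as a step. Such a move is expected in this assay, of uncertain size, and another result at the limit remains possible. The estimated change is an at least 20-fold lower number from compound 2 to compound 3 (1.30 log units; beyond the scatter) on this reading. For compound 3 the estimate is 5000 nM as the expected value, with an expected range from 200 nM up to 100000 nM in this assay.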

Compound 3, half-maximal inhibitory concentration: 1200 nM
Compound 3: middle estimate off by 4.2-fold (0.62 log units), on the high side; low and high end bracket the measured number.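

In this assay, the group on the aromatic nitrogen now has a measured step: 4-methoxyphenyl in place of benzyl gives an at least 83-fold lower number from compound 2 to compound 3 (1.92 log units; beyond the scatter). Compound 2 gives > 100000 nM, which is a limit and not a number, so this step fixes only a smallest size and leaves the true size unknown. Even so, this place, on an aromatic nitrogen of the five-membered ring and next to the ring atom that bears a large group, is now shown to respond to a single change, and the series gains its first value away from the limit that otherwise holds the data: the limit of > 100000 nM in this assay, at which 2 of the 3 values shown sit.

The one step exchanges benzyl for 4-methoxyphenyl as a whole, so the compounds shown do not separate the part played by the methoxy group from the way the six-membered ring is attached to the nitrogen. As far as these compounds go, how an unsubstituted phenyl, a 4-aminophenyl or a longer chain ending in a carboxylic acid would read at this same place in this assay remains open.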